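Swapping the aryl group on a coumarin-like scaffold

The compounds below may be only part of what the source reports. "The series", "measured", "known", "first", "only" and "open" are said of these compounds alone.

Within the data shown here, compound 2 `C#CCOC(=O)CC1C(C(=O)OCC#C)=C(N)Oc2ccc(-c3cc(OC)cc(OC)c3)cc21` is the strongest of the three compounds measured so far: in a functional assay on HL-60 cells (Homo sapiens) for cytotoxicity, read by CellTiter-Blue, with a stated time of 48 h (a lower number here means a stronger inhibitor, a higher number a weaker inhibitor), compound 2 gives 1500 nM. Its nearest neighbour is compound 3 `C#CCOC(=O)CC1C(C(=O)OCC)=C(N)Oc2ccc(-c3cc(OC)cc(OC)c3)cc21`, which gives 4700 nM, and the gap between them, a 3.1-fold higher number from compound 2 to compound 3 (0.50 log units; beyond the scatter), comes from a change in one ester chain only. Further away lies compound 1 `CCCOC(=O)CC1C(C(=O)OCCC)=C(N)Oc2ccc(-c3cc(OC)cc(OC)c3)cc21`, with 7600 nM.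

Compound 4 `C#CCOC(=O)CC1C(C(=O)OCC#C)=C(N)Oc2ccc(-c3ccc(NCC)cc3)cc21` keeps both propargyl esters of compound 2 and changes the aromatic substituent instead: 4-(ethylamino)phenyl in place of 3,5-dimethoxyphenyl on an aromatic carbon. Among the measured compounds shown here, no measured step touches this part of the molecule; the only step known, from compound 2 to compound 3, concerns the ester chains, so it says nothing about how the aryl group matters. Without a comparable step the direction of the change cannot be read from the data, and the best guide is that the shared core and esters are held fixed.

Compound 4 is therefore expected to land close to compound 2, with the step of a 1.3-fold higher number from compound 2 to compound 4 (0.12 log units; within the scatter) estimated as no more than the spread seen among the three measured compounds. The estimate for compound 4 is 2000 nM, within a range from 500 nM to 8000 nM.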

Compound 4, half-maximal inhibitory concentration: 7270 nM
Estimate against measurement, compound 4: 3.6-fold (0.56 log units) below; the range from low to high includes it.
By their numbers in this assay, from the lowest: compound 2; then compounds 3, 4 and 1 (each within the scatter of the next).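

The aryl group on the shared core is not a silent position. In this assay, with both propargyl esters held fixed, putting 4-(ethylamino)phenyl in place of 3,5-dimethoxyphenyl gives a 4.8-fold higher number from compound 2 to compound 4 (0.69 log units; beyond the scatter), so a change on this aromatic carbon can move the number as clearly as a change in the esters. Among these compounds, until now the only step on record, a 3.1-fold higher number from compound 2 to compound 3 (0.50 log units; beyond the scatter), lay in one ester chain, whereas these two steps, both beyond the scatter, show that the ester chains and the aryl group each count for this number. The swap alters the substituents on the phenyl ring and where they sit in a single move, and nothing measured here explains why the number rises.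

The compounds shown leave open whether losing the two methoxy groups or gaining the ethylamino group matters more, and what a plain phenyl, a 4-methoxyphenyl or a 3-(ethylamino)phenyl group would give at this position. They also leave open whether replacing a propargyl ester with an ethyl ester would raise the number in the same way with 4-(ethylamino)phenyl in place.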